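Carbamoyl to (ethylsulfanyl)carbonyl on the furan-bearing core

The compounds below may be only part of what the source reports. "The series", "measured", "known", "first", "only" and "open" are said of these compounds alone.

Compound 2 `CC1=C(C(N)=O)C(c2ccoc2)NC(=O)N1` gives 6% in an assay on membranes from HEK293 cells for displacement of a labelled ligand from adenosine receptor A2b (Homo sapiens), read by scintillation counting, with a stated time of 30 min, tested at 1 uM (on this read-out lower numbers stand for less inhibition and higher numbers for more inhibition at the one concentration tested (going by the name of the read-out)), the second highest of the three numbers measured. Compound 3 `CC1=C(C(N)=O)C(c2ccsc2)NC(=O)N1` gives 1% in this assay, and the step of a number 5 percentage points lower from compound 2 to compound 3 (within the scatter) lies within the scatter. Within the data shown here, compound 1 `CC1=C(C(=O)CC(C)C)C(c2cccs2)NC(=O)N1` gives 43% in this assay, a gap to compound 2 that lies beyond the scatter, but compound 1 differs from compound 2 in more than one place, so its value alone carries no single step. Compound 4 `CCSC(=O)C1=C(C)NC(=O)NC1c1ccoc1` differs from compound 2 by ethylsulfanyl in place of amino on a carbonyl carbon. Among the measured compounds shown here, no measured step touches this position directly. A modest rise is nevertheless expected, a number 14 percentage points higher from compound 2 to compound 4 (beyond the scatter), with compound 4 estimated at 20% in this assay, within a range from 0% to 45%.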

Compound 4, a percentage reported as inhibition, at one concentration (the size of the read-out at that concentration, not a potency): 1%
Beside the measured number, compound 4's estimate is 19 percentage points above it; the measured number falls inside the stated range.
By their numbers in this assay, from the lowest: compounds 3, 4 and 2 (each within the scatter of the next); then compound 1.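

In this assay, among these compounds, the step of a number 5 percentage points lower from compound 2 to compound 4 (within the scatter) gives the first reading at this position: with ethylsulfanyl in place of amino on a carbonyl carbon, the two compounds stay within the scatter of each other. Losing the amino group and bringing in the larger ethylsulfanyl chain therefore gives no separable difference on this core. No measured evidence bears on this result. Still open, going by these compounds, is how a methylamino group, a carboxylic acid or a longer chain on this carbonyl carbon would read, and whether the same change would read alike with thiophen-3-yl on the core.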